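The source may hold more compounds than are shown below. What is called first, only, known or untested is meant among the compounds shown, and "the series" means these compounds.

Measured so far:
- compound 1, `O=C1NC(=S)/C(=C/c2ccc(Br)cc2)S1`: 1.1%
- compound 2, `O=C1NC(=S)/C(=C/c2cc(Cl)cc(Cl)c2Cl)S1`: 14.2%

Both compounds share the same core and differ only in the substituents on the aromatic ring. In a functional assay on NCI-H292 cells (Homo sapiens) for cytotoxicity, read by MTT assay, with a stated time of 72 h, tested at 1.25 ug/mL (a higher number here means more inhibition of growth at the concentration tested, a lower number less inhibition of growth), compound 1 gives 1.1%, the lowest of the two numbers available. Compound 2 gives 14.2% in this assay, a higher number, and the gap between the two lies beyond the usual scatter. Within the data shown here, no pair of compounds differing in only one place has been measured, so there is no single-change step to lean on.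

Compound 3, `O=C1NC(=S)/C(=C/c2ccc(F)cc2)S1`, has not yet been measured in this assay. It differs from compound 1 in one respect: fluoro in place of bromo on an aromatic carbon. Since only halogen identity changes at the same place on the ring, and since compound 1 gives 1.1%, a number close to the bottom of the scale, the expected step from compound 1 to compound 3 is a number 1.9 percentage points higher from compound 1 to compound 3 (within the scatter), in no direction beyond the scatter. Compound 3 is therefore estimated at 3% in this assay, within a range of 0% to 14%.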

Compound 3, percent growth inhibition at one concentration: 7.32%
Estimate against measurement, compound 3: 4.3 percentage points below, within the range that was stated.
By their numbers in this assay, from the lowest: compounds 1, 3 and 2 (each within the scatter of the next, the first and the last beyond it).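

In this assay, among these compounds, the exchange of bromo for fluoro, on an aromatic carbon para to a group of 8 heavy atoms, gives a number 6.2 percentage points higher from compound 1 to compound 3 (within the scatter) and provides the first comparison in which only one place changes. At this position, then, replacing one halogen with the other does not move growth inhibition beyond the variation expected between repeated measurements, even though the two atoms differ in identity. Nothing among the data shown accounts for this small step or says how either halogen behaves in the cells.

The compounds shown carry only halogens on the aromatic ring, so it remains open whether an amine, a carboxylic acid or a methoxy group at this same place would leave the number just as unchanged or shift it clearly. A single chloro or a plain hydrogen at this place would also show whether the halogens tested here stand for a wider flat stretch, and readings at other concentrations would show whether the step stays this small.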